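The compounds below may be only part of what the source reports. "The series", "measured", "known", "first", "only" and "open" are said of these compounds alone.

Three compounds that share a core, each carrying a differently substituted aromatic ring, have been tested in an assay on isolated protein for inhibition of alpha-galactosidase (Coffea arabica), tested at 1000 uM; a lower number here means less inhibition, a higher number more inhibition at the concentration tested (going by the name of the read-out). Compound 1 `COc1ccc([C@]2(CO)NC[C@@H](O)[C@@H]2O)cc1` gives 7.5%. Compound 2 `OC[C@@]1(c2cccc(F)c2)NC[C@@H](O)[C@@H]1O` gives 0%. Compound 3 `COc1cccc([C@@]2(CO)NC[C@H](O)[C@H]2O)c1` gives 1.6%. All three numbers lie within the usual scatter of one another, so none of these compounds can be said to inhibit more or less than the others. Compound 3 has the second highest of the three numbers, with compound 2 nearest and compound 1 furthest, both gaps within the scatter.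

Compound 4 `COc1ccc([C@@]2(CO)NC[C@H](O)[C@H]2O)cc1OC` has not yet been measured. It differs from compound 3 in one place: methoxy in place of hydrogen on an aromatic carbon. Going by the values given here, no pair of measured compounds shows what such a change does here, so there is no measured step to lean on. Since all three measured compounds sit near the bottom of the scale, the step expected in this assay is a number 1.4 percentage points higher from compound 3 to compound 4 (within the scatter), that is, none beyond the scatter. For compound 4 the estimate is 3%, with a range from 0% to 12%.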

Compound 4, a percentage reported as inhibition, at one concentration (the size of the read-out at that concentration, not a potency): 0%
Compound 4: the middle estimate sits 3 percentage points above what was measured, within the range that was stated.
By their numbers in this assay, from the lowest: compounds 2, 4, 3 and 1 (each within the scatter of the next).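

Going by these compounds alone, this is the first pair in this assay that differs in only one place, and it gives a number 1.6 percentage points lower from compound 3 to compound 4 (within the scatter). On this aromatic carbon, ortho to a methoxy group and para to a group of 9 heavy atoms, methoxy in place of hydrogen therefore produces no change that can be told apart from the usual scatter. No available evidence bears on the reason for this result.

As far as these compounds go, it remains open whether a different group on this same carbon, such as a carboxylic acid or a longer chain, would move the number beyond the scatter. From the compounds shown here alone, it is also open whether methoxy in place of hydrogen at this carbon would give a similar step on an aromatic ring without the existing methoxy group.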